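The source may hold more compounds than are shown below. What is called first, only, known or untested is meant among the compounds shown, and "the series" means these compounds.

Working notes on the benzothiazolylthioacetamide series.

Three compounds share one core and differ only in the aryl group on the saturated chain carbon bound to the amide-type nitrogen. Compound 1 `COc1cc(N(Cc2ccccc2)C(=O)CSc2nc3ccccc3s2)cc(OC)c1OC` carries a plain phenyl there and gives 44300 nM in a functional assay on MGC-803 cells (Homo sapiens) for antiproliferative activity, read by MTT assay, with a stated time of 48 h; a higher number here means a weaker inhibitor, a lower number a stronger inhibitor. Compound 2 `COc1ccc(CN(C(=O)CSc2nc3ccccc3s2)c2cc(OC)c(OC)c(OC)c2)cc1F` carries 3-fluoro-4-methoxyphenyl and gives 416 nM. Compound 3 `COc1cc(CN(C(=O)CSc2nc3ccccc3s2)c2cc(OC)c(OC)c(OC)c2)cc(OC)c1OC` carries 3,4,5-trimethoxyphenyl and gives 45700 nM. Compound 3 is at the weak end of the three, and compound 1 sits within the scatter of it, the step being a 1.0-fold higher number from compound 1 to compound 3 (0.01 log units; within the scatter). The one large movement seen so far is a 110-fold lower number from compound 1 to compound 2 (2.03 log units; beyond the scatter), mirrored by a 110-fold higher number from compound 2 to compound 3 (2.04 log units; beyond the scatter).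

Compound 4 `COc1ccc(CN(C(=O)CSc2nc3ccccc3s2)c2cc(OC)c(OC)c(OC)c2)cc1[N+](=O)[O-]` is not yet measured. Its change from compound 3 is 4-methoxy-3-nitrophenyl in place of 3,4,5-trimethoxyphenyl on a saturated chain carbon bound to an amide-type nitrogen. Among the measured compounds shown here, the step bearing on it most directly is a 110-fold higher number from compound 2 to compound 3 (2.04 log units; beyond the scatter): the entering group shares the 4-methoxy pattern of compound 2 and differs from it in the group at the 3-position only, so a large downward step from compound 3 is expected, though its size is uncertain since the 3-nitro group has no precedent. For compound 4 the expected value is 2000 nM, within 300 nM to 15000 nM, which amounts to an expected step of a 23-fold lower number from compound 3 to compound 4 (1.36 log units; beyond the scatter).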

Compound 4, half-maximal inhibitory concentration: 682 nM
Estimate against measurement, compound 4: 2.9-fold (0.47 log units) above; measured number inside the range.
By their numbers in this assay, from the lowest: compounds 2 and 4 (each within the scatter of the next); then compounds 1 and 3 (each within the scatter of the next).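

The 4-methoxy-3-nitrophenyl group in this assay gives a 67-fold lower number from compound 3 to compound 4 (1.83 log units; beyond the scatter) and a 65-fold lower number from compound 1 to compound 4 (1.81 log units; beyond the scatter), so a large step at this saturated chain carbon bound to an amide-type nitrogen is no longer confined to compound 2, and it now appears with a second aryl group. Nitro in place of fluoro on an aromatic carbon gives a 1.6-fold higher number from compound 2 to compound 4 (0.21 log units; within the scatter), within the scatter, so compound 2 and compound 4 cannot be told apart here, although both carry a 4-methoxy-substituted aryl group; compound 3 goes against any reading of that shared group as enough by itself, since its 3,4,5-trimethoxyphenyl group also has a methoxy at the 4-position and stays with compound 1 at the weak end. No measured evidence at hand accounts for these steps or for the tolerance of both nitro and fluoro.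

Still open, going by these compounds, is whether an amine or a carboxylic acid in place of the nitro on an aromatic carbon would stay with compound 2 and compound 4 or fall back towards compound 3. Also open, on these data alone, is whether the fluoro or nitro group would hold this level on a phenyl ring without the methoxy group.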